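This account rests on a few compounds, and the source may have more. Where it says the series, first, only, none or still open, it means among the compounds named here.

In a functional assay on HepG2 cells (Homo sapiens) for cytotoxicity, read by MTT assay, with a stated time of 72 h (a lower number here means a stronger inhibitor, a higher number a weaker inhibitor), compound 3, `Cc1cc(=O)n(-c2ccccc2C(F)(F)F)nc1C(=O)Nc1ccc(Oc2ncnc3sccc23)c(F)c1`, gives 14700 nM. Of the two numbers that are actually known, this is the higher one, and its nearest neighbour is compound 2, `Cc1cc(=O)n(-c2ccccc2C(F)(F)F)nc1C(=O)Nc1ccc(Oc2ncnc3ccsc23)c(F)c1`, which gives 9380 nM in this assay. The two compounds differ only in the arrangement of the bicyclic ring carried on the ether oxygen, and the step of a 1.6-fold higher number from compound 2 to compound 3 (0.20 log units; within the scatter) lies within the scatter of repeated measurements, so no real difference between them can be claimed. Compound 1, `CNC(=O)c1cc(Oc2ccc(NC(=O)c3nn(-c4ccccc4OC(F)(F)F)c(=O)cc3C)cc2F)ccn1`, reaches only the limit of the assay, > 40000 nM, which is a limit and not a number; this is the case described as the limit of > 40000 nM in this assay, at which 1 of the 3 values shown sits.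

Compound 4, `Cc1cc(=O)n(-c2ccccc2OC(F)(F)F)nc1C(=O)Nc1ccc(Oc2ncnc3sccc23)c(F)c1`, is compound 3 with a single change: trifluoromethoxy in place of trifluoromethyl on an aromatic carbon. Going by the values given here, no measured step touches this position, and compound 1, the only other compound carrying trifluoromethoxy, differs from compound 4 in more than one place, so its limit value cannot be read as a step. Among the compounds with values here, the one measured step, from compound 2 to compound 3, was small and concerned a different part of the molecule. With nothing pointing in either direction, the expectation for compound 4 is a change of about a 1.2-fold higher number from compound 3 to compound 4 (0.06 log units; within the scatter), no larger than the scatter. Compound 4 is therefore estimated to give 17000 nM in this assay, with a likely range from 6000 nM to 45000 nM.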

Compound 4, half-maximal inhibitory concentration: > 40000 nM
Compound 4 ended at the assay's limit; the forecaster's own chance of this, stated with the estimate: 25%; middle value at least 2.3-fold (0.37 log units) away from the limit.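

In this assay, going by these compounds alone, trifluoromethoxy in place of trifluoromethyl gives an at least 2.7-fold higher number from compound 3 to compound 4 (0.43 log units; beyond the scatter), the first measured step at this position, and it lies beyond the scatter, so this group on the ring does affect the reading. Going by these compounds, compound 4 stands at a limit of the assay rather than at a number, so the full size of this step remains unknown. The step from compound 1 to compound 4 cannot be read, but among the compounds shown, the two carrying trifluoromethoxy are the two that share this result, while the two carrying trifluoromethyl give numbers: the limit of > 40000 nM in this assay, at which 2 of the 4 values shown sit.

On these data alone, it remains open how a methoxy group, a chlorine atom or a plain hydrogen would read at this position in this assay, and so whether the oxygen of trifluoromethoxy matters or the larger group as a whole. Also open, as far as these compounds go, is whether the same change would shift compound 2, which carries the other arrangement of the bicyclic ring, by a similar amount.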